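Swapping a Pyrazole for Methoxy in an Adrenergic Agonist

The compounds below may be only part of what the source reports. "The series", "measured", "known", "first", "only" and "open" are said of these compounds alone.

Compound 1, `COc1c(C)ccc2c1CCC2c1ncc[nH]1`: 40%
Compound 2, `c1cc(-c2ccn[nH]2)c2c(c1)C(c1ncc[nH]1)CC2`: 83%

Both numbers come from a functional assay on CHO cells for agonist activity at Alpha-1A adrenergic receptor (Homo sapiens), read by FLIPR and calcium flux; on this read-out lower numbers stand for smaller maximal responses and higher numbers for larger maximal responses. Compound 2 stands higher of the two, with compound 1 sitting well beyond the scatter below it. Compound 3, `COc1cccc2c1CCC2c1ncc[nH]1`, is still unmeasured; it arises from compound 2 by methoxy in place of 1H-pyrazol-5-yl on an aromatic carbon. Compound 1 carries that same methoxy alongside a methyl, and its 40% in this assay is the closest guide available, so a drop is expected. Compound 3 is estimated at 50%, between 25% and 80%. The expected step is a number 33 percentage points lower from compound 2 to compound 3 (beyond the scatter).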

Compound 3, largest response reached (Emax), in percent of the reference or control that the assay uses: 65%
Compound 3: the middle estimate sits 15 percentage points below what was measured; the measured number falls inside the stated range.
By their numbers in this assay, from the lowest: compound 1; then compound 3; then compound 2.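

Methoxy in place of 1H-pyrazol-5-yl gives a number 18 percentage points lower from compound 2 to compound 3 (beyond the scatter) and so shows that a group with no ring can still leave a sizable response at this aromatic carbon. Hydrogen in place of methyl on an aromatic carbon gives a number 25 percentage points higher from compound 1 to compound 3 (beyond the scatter) and so shows that the response depends on more than the methoxy alone. Nothing measured here explains either step.

Still open, going by these compounds, is whether an amine or a chlorine at this aromatic carbon would match the pyrazole. Also open, on these data alone, is how a methyl would act without the methoxy.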